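Phenyl in place of tert-butyl on the thiourea nitrogen

A few compounds are considered here, and "the series" means these few. Any claim that something is new, unique, unknown or untested is made for them only; others in the source may bear on it.

Three acylthioureas sharing one core have been measured so far. Compound 1 `O=C(NC(=S)Nc1ccc(Oc2ccccc2)cc1)c1ccccc1` gives 2100 nM in an assay for inhibition of epoxide hydrolase 1 (Homo sapiens), read by fluorescence, using microsomes; on this read-out lower numbers stand for stronger inhibition and higher numbers for weaker inhibition. Compound 2 `O=C(NC(=S)Nc1ccncc1)c1ccccc1` gives 2280 nM. Compound 3 `CC(C)(C)NC(=S)NC(=O)c1ccccc1` gives 1580 nM, a number that sits within the usual scatter of both compound 1 and compound 2. For the measured compounds named here, the only step measured so far between two compounds differing in one place, a 1.4-fold lower number from compound 2 to compound 3 (0.16 log units; within the scatter), exchanged an aromatic ring for tert-butyl on the amide-type nitrogen and did not leave the scatter.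

Compound 4 `O=C(NC(=S)Nc1ccccc1)c1ccccc1` has not yet been measured. It differs from compound 3 as follows: phenyl in place of tert-butyl on an amide-type nitrogen. This change is the reverse kind of exchange to the measured step, putting a six-membered carbon ring back where compound 1 and compound 2 also carry an aromatic ring. Since all three measured numbers lie within the scatter of one another, no step beyond the scatter is expected in this assay. Compound 4 is therefore estimated at 2000 nM, with a range from 900 nM to 4500 nM, which means an expected step of a 1.3-fold higher number from compound 3 to compound 4 (0.10 log units; within the scatter).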

Compound 4, half-maximal inhibitory concentration: 1290 nM
Estimate against measurement, compound 4: 1.6-fold (0.19 log units) above; the measured number falls inside the stated range.
By their numbers in this assay, from the lowest: compounds 4, 3, 1 and 2 (each within the scatter of the next).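

In this assay, the exchange of tert-butyl for phenyl on an amide-type nitrogen gives a 1.2-fold lower number from compound 3 to compound 4 (0.09 log units; within the scatter) and so does not separate a group with a six-membered aromatic ring from one with no ring at this position. Phenyl in place of pyridin-4-yl at the same nitrogen gives a 1.8-fold lower number from compound 2 to compound 4 (0.25 log units; within the scatter) and hydrogen in place of phenoxy on an aromatic carbon gives a 1.6-fold lower number from compound 1 to compound 4 (0.21 log units; within the scatter) so that all four compounds remain within the scatter, and neither change shows a measurable effect on this read-out. No evidence is available that bears on this result.

As far as these compounds go, whether an amine, a carboxylic acid or a longer chain on this nitrogen would leave the scatter remains open. The compounds shown also leave open what substituents on the benzoyl phenyl ring would do.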